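Chloro substitution on the aromatic ring of compound 2

The compounds below may be only part of what the source reports. "The series", "measured", "known", "first", "only" and "open" are said of these compounds alone.

Compound 2 `c1cncc(N2C[C@@H]3CCNC[C@@H]32)c1` in a functional assay on HEK293 cells for agonist activity at Neuronal acetylcholine receptor; alpha3/beta4 (Homo sapiens), read by FLIPR (a higher number here means that more compound is needed for the effect, a lower number that less compound is needed), gives 1700 nM, the highest number among the three measured. Its mirror image, compound 3 `c1cncc(N2C[C@H]3CCNC[C@H]32)c1`, gives 1540 nM in this assay; the step of a 1.1-fold lower number from compound 2 to compound 3 (0.04 log units; within the scatter) lies within the scatter, and the fact that compounds 2 and 3 differ only in the configuration as drawn is all that separates the pair. Within the data shown here, compound 1 `N#Cc1cncc(N2CC[C@@H]3CN[C@@H]3C2)c1`, built on a different core and carrying a nitrile, gives 490 nM in this assay, a lower number than compound 2 by a gap beyond the scatter; no single-place step joins the two. Compound 4 `Clc1ccc(N2C[C@@H]3CCNC[C@@H]32)cn1` differs from compound 2 by chloro in place of hydrogen on an aromatic carbon. Among the measured compounds shown here, no measured step alters a substituent on the aromatic ring, so nothing measured bears directly on this change; the one measured step, a stereo inversion, gave a 1.1-fold lower number from compound 2 to compound 3 (0.04 log units; within the scatter) only. The expected step is therefore modest, a 1.9-fold lower number from compound 2 to compound 4 (0.28 log units; within the scatter), with the direction uncertain and a lower number held slightly more likely. For compound 4 the estimate in this assay is 900 nM, between 300 nM and 2700 nM.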

Compound 4, half-maximal effective concentration: 1390 nM
Compound 4: the middle estimate sits 1.5-fold (0.19 log units) below what was measured; the measured number falls inside the stated range.
By their numbers in this assay, from the lowest: compound 1; then compounds 4, 3 and 2 (each within the scatter of the next).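

In this assay, among these compounds, chloro in place of hydrogen on an aromatic carbon gives a 1.2-fold lower number from compound 2 to compound 4 (0.09 log units; within the scatter), the first measured step that alters a substituent on the aromatic ring. At this place, next to the ring nitrogen and para to a group of 8 heavy atoms, chloro is therefore accepted without a step beyond the scatter, so the number stays level with that of compound 2. No information at hand explains this step.

As far as these compounds go, whether an amine, a methoxy group or a carboxylic acid on the same aromatic carbon would give a step beyond the scatter remains open. Also open, from the compounds shown here alone, is whether chloro at this place would behave the same way on the mirror-image compound 3 or on the core of compound 1.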